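A cyano group added onto a tetrazole-bearing hydrazone

This account rests on a few compounds, and the source may have more. Where it says the series, first, only, none or still open, it means among the compounds named here.

Of the compounds shown here, three from this series have been tested in a functional assay on C6 cells (Rattus norvegicus) for cytotoxicity, read by MTT assay, with a stated time of 24 h; a lower number here means a stronger inhibitor, a higher number a weaker inhibitor. Compound 2 `Cn1cnnc1SCC(=O)N/N=c1/scc(-c2ccccc2)n1-c1ccccc1` gives 68.3 ug/mL in this assay. Compound 1 `Cn1cnnc1SCC(=O)N/N=c1/scc(-c2ccc(C#N)cc2)n1-c1ccccc1` differs from compound 2 by cyano in place of hydrogen on an aromatic carbon. In this assay compound 1 reaches only a limit of the assay, > 200 ug/mL. That change made an at least 2.9-fold higher number from compound 2 to compound 1 (0.46 log units; beyond the scatter), its size known only as far as the limit of > 200 ug/mL in this assay, at which 1 of the 3 values shown sits, allows. Compound 3 `O=C(CSc1nnnn1-c1ccccc1)N/N=c1/scc(-c2ccccc2)n1-c1ccccc1` carries a different core, the difference being (1-phenyl-1H-tetrazol-5-yl in place of 4-methyl-4H-1,2,4-triazol-3-yl on a sulfur); in this assay compound 3 gives 8.3 ug/mL, and this change made an 8.2-fold lower number from compound 2 to compound 3 (0.92 log units; beyond the scatter). Compound 4 `N#Cc1ccc(-c2cs/c(=N/NC(=O)CSc3nnnn3-c3ccccc3)n2-c2ccccc2)cc1` has not yet been measured. It differs from compound 3 by cyano in place of hydrogen on an aromatic carbon, the same change as that from compound 2 to compound 1, at the same place on the ring. Compound 4 is expected to show a weakening step, a 4.2-fold higher number from compound 3 to compound 4 (0.62 log units; beyond the scatter), in line with an at least 2.9-fold higher number from compound 2 to compound 1 (0.46 log units; beyond the scatter), a step whose full size the limit of compound 1 hides. On that basis compound 4 is estimated at 35 ug/mL, with a range from 12 ug/mL to 150 ug/mL.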

Compound 4, half-maximal inhibitory concentration: > 200 ug/mL
Compound 4 ended at the assay's limit; the forecaster's own chance of this, stated with the estimate: 15%; middle value at least 5.7-fold (0.75 log units) away from the limit.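

Going from phenyl to 4-cyanophenyl pushed the number up on both cores in this assay, and on the core of compound 3 the change made an at least 24-fold higher number from compound 3 to compound 4 (1.38 log units; beyond the scatter). The direction of the change therefore carried over in these two pairs, which is too little to make a rule for the series, and its size cannot be compared between the cores: the same change on two cores in this assay, an at least 2.9-fold higher number (0.46 log units; beyond the scatter) from compound 2 to compound 1 and an at least 24-fold higher number (1.38 log units; beyond the scatter) from compound 3 to compound 4; the limit leaves it open whether they differ Compound 4 gives > 200 ug/mL, which is a limit of the assay and not a number, and the step between compound 1 and compound 4 cannot be read.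

The compounds shown leave open whether other groups at this place on the ring, such as a fluorine atom, a methoxy group or a carboxylic acid, would raise the number in the same way. Also open, on these data alone, is whether swapping 4-methyl-4H-1,2,4-triazol-3-yl for 1-phenyl-1H-tetrazol-5-yl, which lowered the number without the cyano group, still does so with it.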